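Fluoro for methoxy: a small change on compound 2

The source may hold more compounds than are shown below. What is called first, only, known or untested is meant among the compounds shown, and "the series" means these compounds.

Measured compounds and their numbers:
compound 1, `N=C(N)c1ccc(-c2ccc(-c3cc(Cl)cc(Cl)c3)s2)s1`: 2390 nM
compound 2, `COc1ccc(-c2ccc(-c3ccc(C(=N)N)o3)o2)cc1`: 3190 nM
compound 3, `N=C(N)c1ccc(-c2ccc(-c3cncc4ccccc34)s2)s1`: 1830 nM

All three were tested in a functional assay on OVCAR-8 cells (Homo sapiens) for inhibition, read by sulforhodamine B assay, with a stated time of 48 h; on this read-out higher numbers stand for weaker inhibition of growth and lower numbers for stronger inhibition of growth. Compound 2 has the highest of the three numbers, yet its gap to compound 1 and its gap to compound 3 both fall within the usual scatter of repeated measurements, so the three compounds cannot be put in any order of strength on these numbers alone.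

Compound 4, `N=C(N)c1ccc(-c2ccc(-c3ccc(F)cc3)o2)o1`, has not yet been measured. It differs from compound 2 in one place: fluoro in place of methoxy on an aromatic carbon.

Among the measured compounds shown here, no pair of measured compounds differs in exactly one place, so there is no earlier step of this kind to lean on. The change is small in what it removes and adds, and the expectation is a step of a 1.1-fold lower number from compound 2 to compound 4 (0.03 log units; within the scatter) that stays within the scatter, in no clear direction. For compound 4 in this assay the estimated value is 3000 nM, with a range from 1200 nM to 7500 nM.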

Compound 4, concentration for 50% growth inhibition: 1980 nM
Beside the measured number, compound 4's estimate is 1.5-fold (0.18 log units) above it; the measured number falls inside the stated range.
By their numbers in this assay, from the lowest: compounds 3, 4, 1 and 2 (each within the scatter of the next).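

In this assay, putting fluoro in place of methoxy on the six-membered aromatic ring, para to a large group, gives a 1.6-fold lower number from compound 2 to compound 4 (0.21 log units; within the scatter). Among the compounds shown here, this is the first comparison here between compounds that differ in only one place, and the earlier compounds could not offer one. It shows that, on this core, methoxy with its hydrogen-bond acceptor can give way to the smaller fluoro, which has none, without a step that can be told apart from the scatter. Nothing measured here bears on why the number stays within the scatter.

Going by these compounds, it remains open whether an amine or a carboxylic acid at this same position would give a step beyond the scatter. On these data alone, it is also open whether fluoro in place of methoxy would give a similar step on the core of compound 1.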